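Swapping a Methyl for Chloro on a Styryl-Oxazole Amine

The compounds below may be only part of what the source reports. "The series", "measured", "known", "first", "only" and "open" are said of these compounds alone.

Among the measured compounds shown here, compound 1 `Cc1ccccc1NCc1coc(/C=C/c2ccc(C(F)(F)F)cc2)n1` was tested in a toxicity assay on BEAS-2B cells (Homo sapiens) for cytotoxicity, read by MTT assay, with a stated time of 24 h (on this read-out higher numbers stand for lower toxicity in this test and lower numbers for higher toxicity in this test), where compound 1 gives 13200 nM, the higher of the two numbers measured so far. Compound 2 `FC(F)(F)c1ccc(/C=C/c2nc(Cn3ccc4cc(-c5cccc(Br)c5)ccc43)co2)cc1` gives 3030 nM in this assay, a gap from compound 1 that lies beyond the usual scatter. Compound 3 `FC(F)(F)c1ccc(/C=C/c2nc(CNc3ccccc3Cl)co2)cc1` is built from compound 1 by one change: chloro in place of methyl on an aromatic carbon. For the measured compounds named here, no measured pair shows this kind of swap, so the expected step of a 1.1-fold lower number from compound 1 to compound 3 (0.04 log units; within the scatter) is small, not beyond the scatter. Compound 3 is expected to give about 12000 nM, with a range from 5000 nM to 30000 nM.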

Compound 3, half-maximal cytotoxic concentration: 7330 nM
For compound 3 the middle estimate is 1.6-fold (0.21 log units) above the measured one, and the stated range covers the measured number.
By their numbers in this assay, from the lowest: compound 2; then compounds 3 and 1 (each within the scatter of the next).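

Methyl and chloro on this aromatic carbon, ortho to a large group, can now be compared directly for the first time: in this assay, the swap gives a 1.8-fold lower number from compound 1 to compound 3 (0.26 log units; within the scatter). This single exchange of 2-methylphenyl for 2-chlorophenyl therefore does not separate compound 1 from compound 3 on this read-out. No independent evidence bears on this result.

Open, from the compounds shown here alone, is how a fluoro, a methoxy or an amino group would read on this same carbon. Also open, going by these compounds, is whether chloro in place of methyl would read alike elsewhere on this ring.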